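This account rests on a few compounds, and the source may have more. Where it says the series, first, only, none or still open, it means among the compounds named here.

Working notes on the series. Compound 1 `CCNc1nc(-c2ccccc2)nc2c1nnn2Cc1ccccc1F` gives 11 nM in an assay on Cerebral cortex for displacement of a labelled ligand from adenosine receptor A1 (Bos taurus); a higher number here means a weaker inhibitor, a lower number a stronger inhibitor; compound 2 `CCCCNc1nc(-c2ccccc2)nc2c1nnn2Cc1ccccc1F` gives 4.3 nM in this assay; compound 3 `CCCCCCNc1nc(-c2ccccc2)nc2c1nnn2Cc1ccccc1F` gives 25 nM in this assay, the highest number of the three. The measured steps run a 2.6-fold lower number from compound 1 to compound 2 (0.41 log units; beyond the scatter), a 5.8-fold higher number from compound 2 to compound 3 (0.76 log units; beyond the scatter) and a 2.3-fold higher number from compound 1 to compound 3 (0.36 log units; beyond the scatter), all modest and all concerning the length of the chain on the amine nitrogen. Compound 4 `Fc1ccccc1Cn1nnc2c(NC3CCCCC3)nc(-c3ccccc3)nc21` differs from compound 3 by cyclohexyl in place of hexyl on a nitrogen on an aromatic ring. Among the compounds with values here, no measured step covers a ring in place of a chain, so none bears directly; only the chain steps hint that the hexyl number sits high. A modest lowering is therefore expected, estimated as a 3.1-fold lower number from compound 3 to compound 4 (0.49 log units; beyond the scatter). Compound 4 is expected to give 8 nM in this assay, within 2.5 nM to 25 nM.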

Compound 4, inhibition constant: 1.15 nM
For compound 4 the middle estimate is 7.0-fold (0.84 log units) above the measured one; the whole stated range lies above it.
By their numbers in this assay, from the lowest: compound 4; then compound 2; then compound 1; then compound 3.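

With 6 heavy atoms on each side, the change from hexyl to cyclohexyl on the nitrogen gives a 22-fold lower number from compound 3 to compound 4 (1.34 log units; beyond the scatter) in this assay, so heavy-atom count alone does not set the number at this position. Within the data shown here, the ring also outdoes both shorter chains, with a 3.7-fold lower number from compound 2 to compound 4 (0.57 log units; beyond the scatter) and a 9.6-fold lower number from compound 1 to compound 4 (0.98 log units; beyond the scatter) in this assay, and gives the lowest number of the series so far. Nothing available explains this difference between ring and chain.

Still open, from the compounds shown here alone, is whether cyclopentyl, a smaller ring, or isopropyl, a branched chain, would match cyclohexyl, and whether a hydroxyl on the cyclohexyl ring would keep the number this low.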